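Replacing the Iodo Group of Compound 3

A few compounds are considered here, and "the series" means these few. Any claim that something is new, unique, unknown or untested is made for them only; others in the source may bear on it.

In an ADME assay on WI-38 cells (Homo sapiens) for cytotoxicity, read by MTT assay, with a stated time of 72 h (a higher number here means a weaker inhibitor, a lower number a stronger inhibitor), three amides sharing one core have been measured. Compound 1 (`CCNC(=O)CCc1cccc2c1B(O)OC2`) gives > 100000 nM, which is a limit of the assay and not a number. Compound 2 (`O=C(CCc1cccc2c1B(O)OC2)Nc1ccc(F)cc1`) gives 12000 nM. Compound 3 (`O=C(CCc1cccc2c1B(O)OC2)Nc1cccc(I)c1`) gives 71000 nM, the higher of the two actual numbers.

Compound 4 (`O=C(CCc1cccc2c1B(O)OC2)Nc1cccc(-c2ccc(Cl)cc2)c1`) differs from compound 3 by 4-chlorophenyl in place of iodo on an aromatic carbon. Among the measured compounds shown here, no measured step makes this exact change, so the guidance is indirect. All three measured steps alter the group on the amide nitrogen. Exchanging one substituted phenyl group for another gave a 5.9-fold higher number from compound 2 to compound 3 (0.77 log units; beyond the scatter). Replacing ethyl gave an at least 8.3-fold lower number from compound 1 to compound 2 (0.92 log units; beyond the scatter), yet also an at least 1.4-fold lower number from compound 1 to compound 3 (0.14 log units; that floor lies within the scatter), whose floor lies within the scatter. These steps suggest that a change on this phenyl group can shift the number modestly, but they do not settle the direction. A modest fall is the tentative expectation, with wide uncertainty. The expected change is a 2.8-fold lower number from compound 3 to compound 4 (0.45 log units; beyond the scatter). For compound 4, the estimated value is 25000 nM, with an expected range from 6000 nM to 90000 nM.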

Compound 4, half-maximal inhibitory concentration: 9800 nM
For compound 4 the middle estimate is 2.6-fold (0.41 log units) above the measured one, and the stated range covers the measured number.
By their numbers in this assay, from the lowest: compounds 4 and 2 (each within the scatter of the next); then compound 3. At a limit, above all of these: compound 1.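

In this assay, among the compounds shown here, the earlier steps all changed the whole group on the amide nitrogen, whereas this one changes only a substituent on its phenyl ring, on an aromatic carbon meta to a large group, and it gives a 7.2-fold lower number from compound 3 to compound 4 (0.86 log units; beyond the scatter). A single iodine atom can therefore give way to a complete second aromatic ring at this position, and the number falls rather than rises, meaning stronger activity against these cells. Compound 1 alone stands at a limit of the assay, so this step is read between two actual numbers: the limit of > 100000 nM in this assay, at which 1 of the 4 values shown sits.

This single step cannot separate the effect of losing the iodo group from that of adding the ring or its chlorine. From the compounds shown here alone, how a plain phenyl group or an amine would read at this position remains open.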